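The source may hold more compounds than are shown below. What is called first, only, known or untested is meant among the compounds shown, and "the series" means these compounds.

Working notes on the series. The shared core is that of compound 1 `CCOC(=O)C(=O)Nc1cccccc1=O`, and in a functional assay on the whole organism (strain Sprague-Dawley CD) for inhibition, with Rattus norvegicus as the target, read by paw edema, at a dose of 100 mg/kg by the oral route (a higher number here means a stronger effect of the compound at the dose given, a lower number a weaker effect), compound 1 gives 91%, the highest of the three numbers in hand. Compound 2 `CCOC(=O)C(=O)Nc1c(C)ccccc1=O` carries methyl in place of hydrogen on an aromatic carbon and gives 37% in this assay; the step of a number 54 percentage points lower from compound 1 to compound 2 (beyond the scatter). Compound 3 `CCOC(=O)C(=O)Nc1ccccc(Br)c1=O` carries bromo in place of hydrogen on an aromatic carbon and gives 0%; the step of a number 91 percentage points lower from compound 1 to compound 3 (beyond the scatter). Both measured steps thus concern an aromatic carbon of the core and both are large losses.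

Compound 4 `CC(C)(C)OC(=O)C(=O)Nc1cccccc1=O` is not yet measured. Its difference from compound 1 lies elsewhere: tert-butyl in place of ethyl on an oxygen next to a carbonyl group. The core and its aromatic carbons are untouched. Among the compounds with values here, no measured step concerns the oxygen next to a carbonyl group, so the two large losses seen for compound 2 and compound 3 do not bear directly on this change; they only show that the series is sensitive to changes on the ring. With nothing in hand on the ester side, the expectation is a step of a number 13 percentage points lower from compound 1 to compound 4 (beyond the scatter), that is, no change beyond the scatter, with a wide margin for a loss. Compound 4 is therefore estimated at 78% in this assay, between 45% and 95%.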

Compound 4, a percentage reported as inhibition, in the whole organism at one dose (the size of the read-out at that dose, not a potency): 82%
For compound 4 the middle estimate is 4 percentage points below the measured one; the range from low to high includes it.
By their numbers in this assay, from the lowest: compound 3; then compound 2; then compounds 4 and 1 (each within the scatter of the next).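

In this assay, within the data shown here, the first reading on the ester side is a number 9 percentage points lower from compound 1 to compound 4 (within the scatter), so compound 1 and compound 4 cannot be told apart, although tert-butyl has 4 heavy atoms where ethyl has 2. The steps on the aromatic carbons, a number 54 percentage points lower from compound 1 to compound 2 (beyond the scatter) and a number 91 percentage points lower from compound 1 to compound 3 (beyond the scatter), are large losses, whereas this exchange on an oxygen next to a carbonyl group shows no loss beyond the scatter, so the sensitivity seen on the ring does not carry over to this change from ethoxy to tert-butoxy. Nothing in hand explains this difference between the two places.

As far as these compounds go, this remains one exchange at one place, so it is open whether a benzyl group or a longer chain on the same oxygen, or a free carboxylic acid or an amide in place of the ester, would also keep the read-out of compound 1. From the compounds shown here alone, with a single oral dose, it is also open whether compound 1 and compound 4 would remain indistinguishable at lower doses.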